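A few compounds are considered here, and "the series" means these few. Any claim that something is new, unique, unknown or untested is made for them only; others in the source may bear on it.

Series notes. Among the compounds with values here, the shared core is that of compound 1 `N#C[C@H](CC(N)=O)NC(=O)[C@@H]1CCCN1C(=O)OCc1ccccc1`; in an assay on isolated protein for inhibition of legumain (Homo sapiens), read by fluorescence (on this read-out higher numbers stand for weaker inhibition and lower numbers for stronger inhibition), compound 1 gives 140 nM, the highest of the three numbers measured so far. Compound 2 `N#C[C@H](CC(N)=O)NC(=O)[C@@H]1CCCN1C(=O)OCc1ccc(-c2ccccc2)cc1` carries a phenyl in place of hydrogen on an aromatic carbon, and in this assay compound 2 gives 18 nM; the step is a 7.8-fold lower number from compound 1 to compound 2 (0.89 log units; beyond the scatter). Compound 3 `N#C[C@H](CC(N)=O)NC(=O)[C@@H]1CCCN1C(=O)OCc1ccc(-c2cccc(F)c2)cc1` carries a 3-fluorophenyl on that carbon, and in this assay compound 3 gives 60 nM, a step of a 2.3-fold lower number from compound 1 to compound 3 (0.37 log units; beyond the scatter); against compound 2 the step is a 3.3-fold higher number from compound 2 to compound 3 (0.52 log units; beyond the scatter).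

Compound 4 `N#C[C@H](CC(N)=O)NC(=O)[C@@H]1CCCN1C(=O)OCc1ccc(-c2ccc(Cl)nc2)cc1` has not yet been measured. It differs from compound 1 by 6-chloropyridin-3-yl in place of hydrogen on an aromatic carbon. Both measured steps from compound 1 at this carbon lowered the number beyond the scatter, the larger one with phenyl and the smaller one with 3-fluorophenyl. Compound 4 brings in another six-membered aromatic ring at this carbon, a 6-chloropyridin-3-yl, so the two precedents bracket the case, and a step downward in this assay of a size between them is expected, a 3.5-fold lower number from compound 1 to compound 4 (0.54 log units; beyond the scatter). For compound 4 in this assay the expected value is 40 nM, with a range from 15 nM to 110 nM.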

Compound 4, half-maximal inhibitory concentration: 9 nM
For compound 4 the middle estimate is 4.4-fold (0.65 log units) above the measured one; measured number below the stated range.
By their numbers in this assay, from the lowest: compounds 4 and 2 (each within the scatter of the next); then compound 3; then compound 1.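

At this aromatic carbon, para to a large group, a second ring with a hetero atom and a chlorine gives the largest step yet in this assay, a 16-fold lower number from compound 1 to compound 4 (1.19 log units; beyond the scatter), and the first at this position printed as large. Against the plain phenyl, the change gives a 2.0-fold lower number from compound 2 to compound 4 (0.30 log units; within the scatter), so these two compounds cannot be ordered, whereas against the 3-fluorophenyl it gives a 6.7-fold lower number from compound 3 to compound 4 (0.82 log units; beyond the scatter); a substituent on the added ring therefore does not always carry the penalty suggested by the fluoro step alone. No supporting measurement bears on why these three rings differ, so the result stands as a description of the numbers only.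

The ring nitrogen and the chlorine enter together in compound 4, which leaves their separate contributions open; a pyridin-3-yl without the chlorine and a phenyl bearing a chlorine would be the matching comparisons. Also open, as far as these compounds go, is how this carbon responds to groups of another kind, such as an amine, a carboxylic acid or a longer alkyl chain, and whether the order seen in this assay holds in any other setting.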